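Triazolylpyridine diaryl ureas: antiproliferative working notes

The compounds below may be only part of what the source reports. "The series", "measured", "known", "first", "only" and "open" are said of these compounds alone.

Measured so far:
compound 1 `CN(C)CCn1cnnc1-c1cc(Oc2ccc(NC(=O)Nc3ccccc3C(F)(F)F)cc2F)ccn1`: > 50000 nM
compound 2 `CN(C)CCn1cnnc1-c1cc(Oc2ccc(NC(=O)Nc3ccc(F)c(F)c3)cc2F)ccn1`: 9050 nM
compound 3 `CN(C)CCCn1cnnc1-c1cc(Oc2ccc(NC(=O)Nc3ccccc3C(F)(F)F)cc2F)ccn1`: 10900 nM

Three compounds on a shared core have been run in a functional assay on NCI-H460 cells (Homo sapiens) for antiproliferative activity, read by MTT assay, with a stated time of 72 h; a lower number here means a stronger inhibitor, a higher number a weaker inhibitor. The value of compound 1 in this assay, > 50000 nM, is a limit of the assay and not a number (the limit of > 50000 nM in this assay, at which 1 of the 3 values shown sits). Compound 2 differs from compound 1 by 3,4-difluorophenyl in place of 2-(trifluoromethyl)phenyl on an amide-type nitrogen; the step is an at least 5.5-fold lower number from compound 1 to compound 2 (0.74 log units; beyond the scatter). Compound 3 differs from compound 1 by (dimethylamino)methyl in place of dimethylamino on a saturated chain carbon, two bonds along the chain from an aromatic nitrogen; the step is an at least 4.5-fold lower number from compound 1 to compound 3 (0.66 log units; beyond the scatter). In this assay compound 2 gives 9050 nM and compound 3 gives 10900 nM, and the two sit within the scatter of each other.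

Compound 4 `CN(C)CCCn1cnnc1-c1cc(Oc2ccc(NC(=O)Nc3ccc(F)c(F)c3)cc2F)ccn1` has not been measured in this assay. It differs from compound 3 by 3,4-difluorophenyl in place of 2-(trifluoromethyl)phenyl on an amide-type nitrogen, the same change made from compound 1 to compound 2, at the same place. The earlier step, an at least 5.5-fold lower number from compound 1 to compound 2 (0.74 log units; beyond the scatter), starts from a limit; its full size is not known. A step of similar size is expected from compound 3 to compound 4: a 3.1-fold lower number from compound 3 to compound 4 (0.49 log units; beyond the scatter). Compound 4 is estimated at 3500 nM, expected between 1200 nM and 10000 nM.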

Compound 4, half-maximal inhibitory concentration: 1080 nM
For compound 4 the middle estimate is 3.2-fold (0.51 log units) above the measured one; the measured number lies below the stated range.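

In this assay, 3,4-difluorophenyl in place of 2-(trifluoromethyl)phenyl on an amide-type nitrogen gives a 10-fold lower number from compound 3 to compound 4 (1.00 log units; beyond the scatter), and the direction matches that of the same change on the other core: the same change on two cores in this assay, an at least 5.5-fold lower number (0.74 log units; beyond the scatter) from compound 1 to compound 2 and a 10-fold lower number (1.00 log units; beyond the scatter) from compound 3 to compound 4; the limit leaves it open whether they differ

(Dimethylamino)methyl in place of dimethylamino on the saturated chain carbon gives an 8.4-fold lower number from compound 2 to compound 4 (0.92 log units; beyond the scatter), again in the same direction as on the other core: the same change on two cores in this assay, an at least 4.5-fold lower number (0.66 log units; beyond the scatter) from compound 1 to compound 3 and an 8.4-fold lower number (0.92 log units; beyond the scatter) from compound 2 to compound 4; the limit leaves it open whether they differ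

Each change therefore carries over in direction within these four compounds, but this does not show that either carries over at the same size, since the value of compound 1 is a limit: the limit of > 50000 nM in this assay, at which 1 of the 4 values shown sits.

The compounds shown leave open whether the number falls further with a longer chain carrying the dimethylamino group, or how a morpholine in place of dimethylamino would read. They also leave open whether an unsubstituted phenyl on the amide-type nitrogen would follow 3,4-difluorophenyl or 2-(trifluoromethyl)phenyl.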